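The source may report more compounds than this note shows. Statements on the series, on what has been measured and on what is new or still open speak of the compounds shown alone.

Values measured so far in an ADME assay on HepG2 2.2.15 cells (Homo sapiens) for cytotoxicity, read by MTT assay; on this read-out lower numbers stand for higher toxicity in this test and higher numbers for lower toxicity in this test

Compound 1 `C=C1CC[C@@H]2[C@](C)(COC(=O)/C=C/c3ccccc3)[C@H](O)CC[C@@]2(C)[C@@H]1/C=C/C1=CCOC1=O` gives 183000 nM
Compound 2 `C=C1CC[C@@H]2[C@](C)(COC(=O)/C=C/c3cccc(Cl)c3)[C@H](O)CC[C@@]2(C)[C@@H]1/C=C/C1=CCOC1=O` gives 147000 nM
Compound 3 `C=C1CC[C@@H]2[C@](C)(COC(=O)c3ccco3)[C@H](O)CC[C@@]2(C)[C@@H]1/C=C/C1=CCOC1=O` gives 92000 nM

These three compounds keep the shared core and differ only in what sits on a carbonyl carbon. Compound 3 carries furan-2-yl there and does not stand apart from the other two, with a 2.0-fold lower number from compound 1 to compound 3 (0.30 log units; within the scatter) and a 1.6-fold lower number from compound 2 to compound 3 (0.20 log units; within the scatter) as the measured steps that reach it. A step of a 1.2-fold lower number from compound 1 to compound 2 (0.10 log units; within the scatter) separates the other pair.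

Compound 4 `C=C1CC[C@@H]2[C@](C)(COC(=O)c3cc(=O)c4ccccc4o3)[C@H](O)CC[C@@]2(C)[C@@H]1/C=C/C1=CCOC1=O` differs from compound 3 by a group of 11 heavy atoms (9 carbon, 2 oxygen; one six-membered aromatic ring of carbon only, one six-membered aromatic ring with 1 hetero atom) in place of a group of 5 heavy atoms (4 carbon, 1 oxygen; one five-membered aromatic ring with 1 hetero atom), on a carbonyl carbon and in nothing else. The two steps that reach compound 3 bear most directly on this change, as both swap the group on this same carbonyl carbon. Among the measured compounds shown here, no measured compound carries the entering group, however, so the data offer no direct precedent and the uncertainty is wide.

Going by a 2.0-fold lower number from compound 1 to compound 3 (0.30 log units; within the scatter) and a 1.6-fold lower number from compound 2 to compound 3 (0.20 log units; within the scatter) as the measured swaps at this place, no step beyond the scatter is expected in this assay in either direction. The expected step is a 1.1-fold higher number from compound 3 to compound 4 (0.04 log units; within the scatter) and it rests on those swaps alone. Compound 4 is estimated at 100000 nM with 40000 nM and 230000 nM as the ends of the expected range.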

Compound 4, half-maximal cytotoxic concentration: 171000 nM
The estimate for compound 4 lay 1.7-fold (0.23 log units) below the measured number; the measured number falls inside the stated range.
By their numbers in this assay, from the lowest: compounds 3, 2, 4 and 1 (each within the scatter of the next).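

In this assay the group of 11 heavy atoms, with its six-membered aromatic ring of carbon only and its six-membered aromatic ring with 1 hetero atom, stays within the scatter of each single-ring group it can be compared with on this carbonyl carbon (a 1.9-fold higher number from compound 3 to compound 4 (0.27 log units; within the scatter)) (a 1.2-fold higher number from compound 2 to compound 4 (0.07 log units; within the scatter)) (a 1.1-fold lower number from compound 1 to compound 4 (0.03 log units; within the scatter)). Among the compounds shown here, the earlier compounds covered only furan-2-yl, 2-phenylethenyl and 2-(3-chlorophenyl)ethenyl, so this is the first sign that a group with two aromatic rings and a second hydrogen-bond acceptor can sit here without a step beyond the scatter in this test. No measurement shown gives any explanation for these numbers.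

The compounds shown leave open whether an amine, a carboxylic acid or a plain saturated carbon chain with no ring on this carbonyl carbon would also stay within the scatter. From the compounds shown here alone, all four compounds also keep the shared core unchanged, so it remains open how the numbers would respond to a change there, such as an acetate ester in place of its free hydroxyl.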